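A few compounds are considered here, and "the series" means these few. Any claim that something is new, unique, unknown or untested is made for them only; others in the source may bear on it.

In an ADME assay on THP-1 cells (Homo sapiens) for cytotoxicity, read by resazurin assay, with a stated time of 48 h (on this read-out lower numbers stand for stronger inhibition and higher numbers for weaker inhibition), compound 1 `O=c1c(O)cccn1Cc1ccc(-c2ccccc2)cc1` gives > 10 ug/mL, which is a limit and not a number. Compound 2 `Cc1ccc(-c2ccc(Cn3cccc(O)c3=O)cc2)cc1` gives > 10 ug/mL, also a limit. Compound 3 `Cc1cccc(-c2ccc(Cn3cccc(O)c3=O)cc2)c1` gives > 10 ug/mL, again a limit, so it has no number of its own. All readings so far sit at one point, (the limit of > 10 ug/mL in this assay, at which 3 of the 3 values shown sit).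

Compound 4 `Cc1ccccc1-c1ccc(Cn2cccc(O)c2=O)cc1` has the same atoms as compound 3, joined differently: 2-methylphenyl in place of 3-methylphenyl on an aromatic carbon. In words, this is 2-methylphenyl in place of 3-methylphenyl on an aromatic carbon.

Among the measured compounds shown here, three measured steps bear on this change: a step that the two limits leave unreadable from compound 1 to compound 2, a step that the two limits leave unreadable from compound 1 to compound 3 and a step that the two limits leave unreadable from compound 2 to compound 3. For the measured compounds named here, the last is the closest precedent, since it also exchanges one methylphenyl for another, but none of the three has a readable size. With a step that the two limits leave unreadable from compound 2 to compound 3 as the nearest guide, no step beyond the scatter is expected, and no direction can be assigned. The expected outcome is a step that the limit leaves unreadable from compound 3 to compound 4, and another limit reading is the most likely report in this assay. Compound 4 is estimated at 20 ug/mL, with an expected range from 10 ug/mL to 50 ug/mL.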

Compound 4, half-maximal inhibitory concentration: > 10 ug/mL
Compound 4 was reported as a limit (the forecaster's own chance of this, stated with the estimate: 85%); the middle value is on the limit's open side.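

No new step can be read: in this assay, compound 4 is reported as a limit, and its comparisons with compound 1, compound 2 and compound 3 each join one limit to another, with all readings at one point: the limit of > 10 ug/mL in this assay, at which 4 of the 4 values shown sit.

The compounds shown leave open whether these four compounds differ at all in cytotoxicity.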